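The source may report more compounds than this note shows. Statements on the series, on what has been measured and on what is new or still open speak of the compounds shown alone.

Compound 1 `Clc1ccc(-c2csc(N/N=C/c3cccs3)n2)cc1` is one of three compounds of a shared core tested in a functional assay, read by spectrophotometry, with a stated time of 15 min, tested at 100 ug/mL (a lower number here means a weaker effect, a higher number a stronger effect of the compound at the concentration tested), and compound 1 gives 87.1% there. Compound 2 `Fc1ccc(-c2csc(N/N=C/c3ccc(Cl)cc3Cl)n2)cc1` gives 95.6% in this assay, and compound 3 `Cc1ccc(-c2csc(N/N=C/c3ccc(Cl)cc3Cl)n2)cc1` gives 85.3%. On these numbers compound 1 stands second highest of the three; its gap to compound 3 and its gap to compound 2 both lie within the usual scatter, so no order among them can be read with confidence. For the measured compounds named here, the one step measured between neighbours is from compound 2 to compound 3, a methyl in place of fluoro on an aromatic carbon, which gave a number 10.3 percentage points lower from compound 2 to compound 3 (beyond the scatter).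

Compound 4 `Fc1ccc(-c2csc(N/N=C/c3cccs3)n2)cc1` differs from compound 1 in one place: fluoro in place of chloro on an aromatic carbon. Going by the values given here, no measured step swaps fluoro for chloro, so the only guidance is indirect: the fluoro-bearing compound 2 holds the highest value, and the one measured step was modest. A small change, if any beyond the scatter, is therefore expected for the step of a number 1.9 percentage points higher from compound 1 to compound 4 (within the scatter). Compound 4 is estimated at 89% in this assay, with an expected range from 76% to 98%.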

Compound 4, a percentage reported as inhibition, at one concentration (the size of the read-out at that concentration, not a potency): 92.4%
Compound 4: middle estimate off by 3.4 percentage points, on the low side; low and high end bracket the measured number.
By their numbers in this assay, from the lowest: compounds 3, 1, 4 and 2 (each within the scatter of the next, the first and the last beyond it).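

With the rest of the molecule unchanged, fluoro in place of chloro on an aromatic carbon, para to a large group, gave a number 5.3 percentage points higher from compound 1 to compound 4 (within the scatter) in this assay. For the compounds shown here, this is the first direct comparison of two halogens at this place, and it shows that exchanging one for the other, one heavy atom for one heavy atom, leaves no difference that can be told from the scatter, at the single concentration tested. No measurement here speaks to why the two groups read alike.

The compounds shown leave open whether this place accepts a group of a different kind, such as an amine, a carboxylic acid or a longer chain like butyl, with a read-out that stays in the same range or one that clearly falls. Also open, on these data alone, is whether the same exchange would read alike on the core carrying the two-chlorine ring of compound 2 and compound 3, and whether a full concentration series would separate compounds that look alike at one concentration.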